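The source may hold more compounds than are shown below. What is called first, only, known or untested is meant among the compounds shown, and "the series" means these compounds.

Working notes on the series. The reference is compound 1 `Cc1ccc(OCC(=O)N(Cc2cccs2)c2cnn(C)c2)cc1`, carrying 1-methyl-1H-pyrazol-4-yl on the amide-type nitrogen. In an assay on HEK293 cells for agonist activity at transient receptor potential cation channel subfamily M member 8 (Homo sapiens), read by fluorescence and calcium flux, with a stated time of 15 min (a higher number here means that more compound is needed for the effect, a lower number that less compound is needed), compound 1 gives 63000 nM, the highest number of the three measured here. Compound 3 `CCN(Cc1cccs1)C(=O)C(C)Oc1ccc(C)cc1`, with an ethyl group in that place, gives 889 nM in this assay, and compound 2 `CCN(Cc1ccoc1)C(=O)COc1ccc(C)cc1`, also ethyl-bearing, gives 136 nM in this assay; both gaps from compound 1 are beyond the scatter. The two ethyl analogues differ elsewhere as well, so only their two values are compared with compound 1, nothing more.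

Compound 4 `Cc1ccc(OCC(=O)N(Cc2cccs2)CC(C)C)cc1` is unmeasured. The change from compound 1 is isobutyl in place of 1-methyl-1H-pyrazol-4-yl on an amide-type nitrogen. Since compound 3 and compound 2, with a small saturated group on that nitrogen, both sit far below compound 1, a sizeable downward step is expected: a step in this assay of a 42-fold lower number from compound 1 to compound 4 (1.62 log units; beyond the scatter), beyond the scatter. In this assay compound 4 is therefore estimated at 1500 nM, expected between 300 nM and 8000 nM.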

Compound 4, half-maximal effective concentration: 900 nM
Beside the measured number, compound 4's estimate is 1.7-fold (0.22 log units) above it, within the range that was stated.
By their numbers in this assay, from the lowest: compound 2; then compounds 3 and 4 (each within the scatter of the next); then compound 1.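

In this assay the pair compound 1 and compound 4 differs only in the group on the amide-type nitrogen, so a 70-fold lower number from compound 1 to compound 4 (1.85 log units; beyond the scatter) belongs to this one change, which compound 2 and compound 3 could not show as they also differ elsewhere. With the rest of the core of compound 1 held fixed, isobutyl in place of 1-methyl-1H-pyrazol-4-yl is enough on its own for a large step. The change removes a five-membered aromatic ring and 2 hydrogen-bond acceptors together, and nothing at hand bears on why the number falls.

On these data alone, it remains open whether a phenyl ring or a cyclopentyl ring on this nitrogen would sit nearer compound 1 or compound 4. As far as these compounds go, a longer chain such as n-hexyl, or a chain ending in an amine, is equally open.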